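Chloro to Fluoro on the Same Aromatic Carbon

The source may report more compounds than this note shows. Statements on the series, on what has been measured and on what is new or still open speak of the compounds shown alone.

Going by the values given here, compound 2 `Cc1ccc(S(=O)(=O)NCc2ccc(CNC(=O)c3ccccc3Cl)cc2)cc1` gives 10 nM in an assay on MDA-MB-231 cells for binding affinity to C-X-C chemokine receptor type 4 (Homo sapiens), read by immunofluorescence and microscopy, with stated times of 10 min and 30 min (on this read-out lower numbers stand for an effect already at smaller amounts and higher numbers for an effect only at larger amounts of compound), the highest of the two numbers measured so far; its nearest neighbour is compound 1 `Cc1ccc(S(=O)(=O)NCc2ccc(CNC(=O)c3ccc(F)cc3)cc2)cc1`, which in this assay gives 1 nM. Among the compounds with values here, the only measured step, a 10-fold higher number from compound 1 to compound 2 (1.00 log units; beyond the scatter), put 2-chlorophenyl in place of 4-fluorophenyl on a carbonyl carbon and so changed the halogen and its place together. Compound 3 `Cc1ccc(S(=O)(=O)NCc2ccc(CNC(=O)c3ccccc3F)cc2)cc1` keeps the place and changes only the halogen: fluoro in place of chloro on an aromatic carbon. Within the data shown here, no measured step separates the two halogens at one place, so the step from compound 1 to compound 2 bears on it only loosely. A shift smaller than that step is expected, toward compound 1, since the fluoro of compound 1 goes with a number of 1 nM. Compound 3 is therefore estimated at about 5 nM in this assay, within a range from 1.5 nM to 20 nM. That estimate means a 2.0-fold lower number from compound 2 to compound 3 (0.30 log units; within the scatter).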

Compound 3, effective concentration (reported as EC, without a stated level of effect): 1000 nM
Compound 3: the middle estimate sits 200-fold (2.30 log units) below what was measured; measured number above the stated range.
By their numbers in this assay, from the lowest: compound 1; then compound 2; then compound 3.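

At this place, ortho to a large group, the identity of the halogen proves to matter strongly: in this assay, fluoro in place of chloro brings a 100-fold higher number from compound 2 to compound 3 (2.00 log units; beyond the scatter) as a large step on a change of one atom. With the halogen held as fluoro, 2-fluorophenyl in place of 4-fluorophenyl brings a 1000-fold higher number from compound 1 to compound 3 (3.00 log units; beyond the scatter) as the largest step among these three compounds, so the earlier step, which changed halogen and place together, combined two separate effects on the number. Nothing available here explains why either the halogen or its place matters so much.

The compounds shown leave open how bromo or methyl would read at this same place, and so whether chloro is the better of a wider series there. They also leave open where 4-chlorophenyl would fall relative to the 4-fluorophenyl of compound 1.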